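Ethyl to Isopropyl on the Amide Nitrogen

The source may hold more compounds than are shown below. What is called first, only, known or untested is meant among the compounds shown, and "the series" means these compounds.

Going by the values given here, compound 2 `CCNC(=O)c1cc(-c2ccc(NS(=O)(=O)c3cccc(Cl)c3Cl)cc2)nc2[nH]ncc12` gives 6 nM in an assay for inhibition of serine/threonine-protein kinase Sgk1 (Homo sapiens), with stated times of 30 min and 60 min, in the presence of a further agent that is not named here (a lower number here means a stronger inhibitor, a higher number a weaker inhibitor), and is the only compound with a plain number there. Compound 1 `CN1CCC(NC(=O)c2cc(-c3ccc(NS(=O)(=O)c4cccc(Cl)c4Cl)cc3)nc3[nH]ncc23)C1` sits at the limit of this assay, < 1 nM. Among the compounds with values here, the one measured step, an at least 6.0-fold higher number from compound 1 to compound 2 (0.77 log units; beyond the scatter), concerns ethyl in place of 1-methylpyrrolidin-3-yl on an amide-type nitrogen, a different change from the one at hand. Compound 3 `CC(C)NC(=O)c1cc(-c2ccc(NS(=O)(=O)c3cccc(Cl)c3Cl)cc2)nc2[nH]ncc12` differs from compound 2 by methyl in place of hydrogen on a saturated chain carbon bound to an amide-type nitrogen and a saturated chain carbon. Within the data shown here, no measured step bears on this, so no shift beyond the scatter is expected in this assay; the expected step is no change at the digits printed from compound 2 to compound 3 (within the scatter). Compound 3 is estimated at 6 nM, between 3 nM and 12 nM.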

Compound 3, half-maximal inhibitory concentration: 68 nM
For compound 3 the middle estimate is 11-fold (1.05 log units) below the measured one; the whole stated range lies below it.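

In this assay the change from ethyl to isopropyl shows that this position is sensitive to one added methyl on the saturated chain carbon bound to the amide-type nitrogen, with an 11-fold higher number from compound 2 to compound 3 (1.05 log units; beyond the scatter) as the result. Isopropyl in place of 1-methylpyrrolidin-3-yl gives an at least 68-fold higher number from compound 1 to compound 3 (1.83 log units; beyond the scatter) as the widest gap among these compounds. Compound 1 gives < 1 nM as a limit of the assay and not a number.

As far as these compounds go, whether cyclopropyl or a straight propyl chain would fare like ethyl or like isopropyl remains open. So does whether an open-chain amine could stand in for the ring of compound 1.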